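Bromo in Place of Phenyl on a Weak Inhibitor

This account rests on a few compounds, and the source may have more. Where it says the series, first, only, none or still open, it means among the compounds named here.

Measured compounds:
compound 1, `C=C[C@@H]1OC(c2ccc(Br)cc2)=N[C@H]1S`, > 100000 nM
compound 2, `C=C[C@@H]1OC(c2ccc(-c3ccccc3)cc2)=N[C@H]1CO`, 24000 nM

In an assay on isolated protein for inhibition of matrix metalloproteinase-9 (Homo sapiens) (a lower number here means a stronger inhibitor, a higher number a weaker inhibitor), compound 2 gives 24000 nM. For the measured compounds named here, that is the only number on record for these compounds; the other entry is a limit of the assay and not a number. For compound 1 the assay reports only a limit, > 100000 nM, which is the limit of > 100000 nM in this assay, at which 1 of the 2 values shown sits. Compound 1 differs from compound 2 in two places at once, so its limit says nothing on its own about either change.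

Compound 3, `C=C[C@@H]1OC(c2ccc(Br)cc2)=N[C@H]1CO`, differs from compound 2 in one place: bromo in place of phenyl on an aromatic carbon. Going by the values given here, no measured pair shows this change by itself, so the size of the step is not known from the data. The expectation is that compound 3 comes out weaker than compound 2 in this assay, by a step beyond the usual scatter, a 2.9-fold higher number from compound 2 to compound 3 (0.46 log units; beyond the scatter). Compound 3 is therefore estimated at 70000 nM, with a range from 15000 nM to 300000 nM, and a real chance that only a limit is reported.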

Compound 3, inhibition constant: 9000 nM
Beside the measured number, compound 3's estimate is 7.8-fold (0.89 log units) above it; measured number outside the range, below it.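

In this assay, for the compounds shown here, the first measured step on the aromatic carbon runs against what compound 2 alone could suggest, since the single bromo atom serves better than the whole phenyl ring it replaces: the change gives a 2.7-fold lower number from compound 2 to compound 3 (0.43 log units; beyond the scatter). The second pair shows that the saturated ring carbon also matters, as hydroxymethyl in place of sulfanyl gives an at least 11-fold lower number from compound 1 to compound 3 (1.04 log units; beyond the scatter), a large step and the larger of the two printed here. Compound 1 is known only through a limit of the assay, so this step has a lower bound and no exact size: the limit of > 100000 nM in this assay, at which 1 of the 3 values shown sits.

On these data alone, with only bromo and phenyl on the aromatic carbon, it remains open how a chloro group, a methoxy group or a nitrile would compare there with bromo in compound 3, which at 9000 nM is still a weak inhibitor. As far as these compounds go, on the saturated ring carbon, it also remains open how an amine, a carboxylic acid or a longer chain ending in a hydroxyl group would compare with the hydroxymethyl of compound 3.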